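This account rests on a few compounds, and the source may have more. Where it says the series, first, only, none or still open, it means among the compounds named here.

Measured compounds:
compound 1, `Cc1ccc2c(=O)c(CSC(=S)N3CCCCC3)coc2c1`, 5100 nM
compound 2, `O=c1c(CSC(=S)N2CCOCC2)coc2cc(Cl)ccc12`, 6200 nM
compound 3, `Cc1ccc2c(=O)c(CSC(=S)N3CCCC3)coc2c1`, 3400 nM

These three compounds share a core and were tested in a functional assay on LM7 cells (Homo sapiens) for antiproliferative activity, read by MTT assay, with a stated time of 72 h; a higher number here means a weaker inhibitor, a lower number a stronger inhibitor. Compound 3 gives the smallest of the three numbers, but both other numbers lie within the usual scatter of it, so the three cannot be told apart with confidence. Among the compounds with values here, the one single-point step among them, a 1.5-fold lower number from compound 1 to compound 3 (0.18 log units; within the scatter), is within the scatter as well.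

Compound 4, `O=c1c(CSC(=S)N2CCCC2)coc2cc(Cl)ccc12`, is not yet measured. It differs from compound 3 by chloro in place of methyl on an aromatic carbon. Within the data shown here, no measured step isolates this exchange: compound 1 carries the methyl and compound 2 the chloro, yet they also differ on the thiocarbonyl carbon. In this assay compound 1 gives 5100 nM. In this assay compound 2 gives 6200 nM. These two numbers alone show only that both sit in the same region. Among the measured compounds shown here, with no step bearing directly on the change, no movement beyond the scatter is expected in this assay.

Compound 4 is therefore estimated at 4500 nM, within a range from 2000 nM to 10000 nM. The expected step is a 1.3-fold higher number from compound 3 to compound 4 (0.12 log units; within the scatter).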

Compound 4, half-maximal inhibitory concentration: 2600 nM
Beside the measured number, compound 4's estimate is 1.7-fold (0.24 log units) above it, within the range that was stated.
By their numbers in this assay, from the lowest: compounds 4, 3, 1 and 2 (each within the scatter of the next, the first and the last beyond it).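

In this assay, chloro in place of methyl on an aromatic carbon now has a step of its own (a 1.3-fold lower number from compound 3 to compound 4 (0.12 log units; within the scatter)), so swapping these two groups at this position makes no difference that can be told from the scatter. Within the data shown here, the same compound also gives the first step beyond the scatter on the thiocarbonyl carbon, a modest one, with pyrrolidin-1-yl in place of morpholin-4-yl (a 2.4-fold lower number from compound 2 to compound 4 (0.38 log units; beyond the scatter)). No measurement at hand explains either step.

On these data alone, whether the morpholin-4-yl exchange gives a similar step on the methyl-bearing core stays open. So does what other groups would do, such as methoxy or a carboxylic acid on that aromatic carbon, or an open-chain diethylamino group on the thiocarbonyl carbon.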